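A few compounds are considered here, and "the series" means these few. Any claim that something is new, unique, unknown or untested is made for them only; others in the source may bear on it.

Within the data shown here, the three compounds measured so far share one core, seen in compound 1 `O=C(Nc1ccc(Cl)cc1)c1cc(=O)[nH]c2cc(Br)ccc12`, compound 2 `O=C(Nc1cc(F)cc(F)c1)c1cc(=O)[nH]c2cc(C(F)(F)F)ccc12` and compound 3 `O=C(Nc1cccc(F)c1)c1cc(=O)[nH]c2cc(-c3ccsc3)ccc12`. In a functional assay on KYSE-70 cells for antiproliferative activity against KYSE-70 cell line (Homo sapiens), read by MTT assay, with a stated time of 72 h (on this read-out higher numbers stand for weaker inhibition and lower numbers for stronger inhibition), compound 1 gives only a limit, > 20000 nM; that is the limit of > 20000 nM in this assay, at which 1 of the 3 values shown sits. Compound 2 gives 14200 nM in this assay. Compound 3 gives 5100 nM in this assay, the lowest of the two numbers, with compound 2 as its nearest neighbour at a higher value, a gap beyond the usual scatter. Compound 4 `O=C(Nc1cccc(F)c1)c1cc(=O)[nH]c2cc(-c3ccc(F)c(CO)c3)ccc12` has not yet been measured. It differs from compound 3 in one place: 4-fluoro-3-(hydroxymethyl)phenyl in place of thiophen-3-yl on an aromatic carbon. Among the measured compounds shown here, no step between measured compounds in this assay is known, so the size of the change from compound 3 to compound 4 rests on expectation alone; a modest lowering of the number, just beyond the scatter, seems the likeliest outcome. Compound 4 is therefore estimated at 2500 nM, within 600 nM to 12000 nM. That estimate means an expected step of a 2.0-fold lower number from compound 3 to compound 4 (0.31 log units; beyond the scatter).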

Compound 4, half-maximal inhibitory concentration: > 20000 nM
Compound 4 was reported as a limit; the forecaster's own chance of this, stated with the estimate: 5%; at least 8.0-fold (0.90 log units) between middle value and limit.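

In this assay, the group on this aromatic carbon of the shared core matters: 4-fluoro-3-(hydroxymethyl)phenyl in place of thiophen-3-yl gives an at least 3.9-fold higher number from compound 3 to compound 4 (0.59 log units; beyond the scatter). Among these compounds, the earlier compounds differed from one another in more than one place, so this is the first change at this position that can be read on its own, and it shows that the measurable activity of compound 3 does not carry over to this six-membered aromatic ring with its substituents. Compound 4 gives only a limit, so the step has a lower bound and no upper one: the limit of > 20000 nM in this assay, at which 2 of the 4 values shown sit.

From the compounds shown here alone, it remains open whether the ring, the fluorine or the hydroxymethyl accounts for the change. Going by these compounds, it is also open whether a plain phenyl, or an aminomethyl group in place of the hydroxymethyl, would give a measurable value at this position.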